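A few compounds are considered here, and "the series" means these few. Any claim that something is new, unique, unknown or untested is made for them only; others in the source may bear on it.

Measured in a functional assay on Raji cells (Homo sapiens) for cytotoxicity, with a stated time of 72 h; on this read-out higher numbers stand for an effect only at larger amounts of compound and lower numbers for an effect already at smaller amounts:
- Compound 1 `CCOc1ccc(/C=C/[C@@](C)(/C=C/c2ccc(O)cc2)CCC=C(C)C)cc1`: > 26000 nM, a limit.
- Compound 2 `CC(C)=CCC[C@](C)(/C=C/c1ccc(O)cc1)/C=C/c1cccc(F)c1`: > 26000 nM, a limit.

Compound 2 has no number in this assay, only the limit > 26000 nM. The next analogue, compound 3 `CC(C)=CCC[C@](C)(/C=C/c1ccc(O)cc1)/C=C/c1cccc(Cl)c1`, carries one change: chloro in place of fluoro on an aromatic carbon, meta to a large group. Within the data shown here, the only measured step that bears on it is a step that the two limits leave unreadable from compound 1 to compound 2. It gives no size, and the data so far amount to the limit of > 26000 nM in this assay, at which 2 of the 2 values shown sit. With no measured size to carry over, no step beyond the scatter is expected in this assay, and another limit is the likeliest report. The expected step is a number no higher from compound 2 to compound 3 (the limit leaves the size open). For compound 3 the estimated value is 26000 nM, with an expected range of 12000 nM to 50000 nM.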

Compound 3, half-maximal effective concentration: > 26000 nM
Compound 3 was reported as a limit; the forecaster's own chance of this, stated with the estimate: 75%; the middle value lies on the limit itself.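

No new step can be read in this assay: compound 1, compound 2 and compound 3 are all reported as limits, so the steps among them cannot be read. The compounds shown leave open whether any change in this series shifts the read-out at all.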